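This account rests on a few compounds, and the source may have more. Where it says the series, first, only, none or still open, it means among the compounds named here.

Compound 1 `COc1cc(-c2nnc3n2NC(c2ccco2)C(C(=O)c2ccc(Br)cc2)S3)cc(OC)c1OC` carries a bromine on the aryl ketone; in a functional assay on A549 cells (Homo sapiens) for cytotoxicity, read by MTT assay, with a stated time of 48 h (on this read-out higher numbers stand for weaker inhibition and lower numbers for stronger inhibition), compound 1 gives 42100 nM. Compound 2 `COc1cc(-c2nnc3n2NC(c2ccco2)C(C(=O)c2cccs2)S3)cc(OC)c1OC` gives 78700 nM and compound 3 `COc1cc(-c2nnc3n2NC(c2ccco2)C(C(=O)c2ccc(Cl)cc2)S3)cc(OC)c1OC` gives 51400 nM. The number for compound 1 is the lowest of the three, yet both other numbers sit within the scatter of it: a 1.2-fold higher number from compound 1 to compound 3 (0.09 log units; within the scatter) and a 1.9-fold higher number from compound 1 to compound 2 (0.27 log units; within the scatter). Compound 4 `COc1cc(-c2nnc3n2NC(c2ccco2)C(C(=O)c2ccc([N+](=O)[O-])cc2)S3)cc(OC)c1OC` differs from compound 1 by nitro in place of bromo on an aromatic carbon. Within the data shown here, no measured pair exchanges bromo for nitro, and the nearest comparison, the halogen swap from compound 1 to compound 3, moved the number hardly at all. A step no larger than the scatter is therefore expected, with no clear direction: a 1.1-fold higher number from compound 1 to compound 4 (0.03 log units; within the scatter). Compound 4 is estimated at 45000 nM, between 20000 nM and 100000 nM.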

Compound 4, half-maximal inhibitory concentration: > 100000 nM
Compound 4 ended at the assay's limit (the forecaster's own chance of this, stated with the estimate: 10%); middle value at least 2.2-fold (0.34 log units) from the limit.
By their numbers in this assay, from the lowest: compounds 1, 3 and 2 (each within the scatter of the next). At a limit, above all of these: compound 4.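

In this assay compound 4 stands at a limit, not at a true number: the limit of > 100000 nM in this assay, at which 1 of the 4 values shown sits. The halogen swap on this aromatic carbon left the number within the scatter, but nitro in place of bromo gives a clear step, an at least 2.3-fold higher number from compound 1 to compound 4 (0.37 log units; beyond the scatter), so this position, para to a large group, does respond to what it carries. The comparisons with the other two settle less, since each is only a floor: an at least 1.9-fold higher number from compound 3 to compound 4 (0.28 log units; that floor lies within the scatter), and an at least 1.2-fold higher number from compound 2 to compound 4 (0.10 log units; that floor lies within the scatter).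

Going by these compounds, what an amine or a carboxylic acid on this aromatic carbon would give stays open.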